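Adding a 6-(dimethylamino)hexyl chain to compound 2

This account rests on a few compounds, and the source may have more. Where it says the series, first, only, none or still open, it means among the compounds named here.

In an ADME assay on HepG2 cells (Homo sapiens) for cytotoxicity, read by luminescence, with a stated time of 72 h (a higher number here means that more compound is needed for the effect, a lower number that less compound is needed), compound 1 `CCOC(=O)c1c(-c2cccc(OCC)c2)[nH]c2cc(OC)ccc2c1=O` gives > 21500 nM, which is a limit and not a number. Compound 2 `CCOC(=O)c1c(-c2cccc(Oc3ccccc3)c2)[nH]c2cc(OC)ccc2c1=O` gives > 21500 nM, which is also a limit. The pair shows a step that the two limits leave unreadable from compound 1 to compound 2, with phenyl in place of ethyl on an oxygen on an aromatic ring. Compound 2 therefore has no number of its own and stands with compound 1 at the limit of > 21500 nM in this assay, at which 2 of the 2 values shown sit.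

Compound 3 `COc1ccc2c(=O)c(C(=O)OCCCCCCN(C)C)c(-c3cccc(Oc4ccccc4)c3)[nH]c2c1` keeps the shared core and the phenyl of compound 2. The change is 4-(dimethylamino)butyl in place of hydrogen on a saturated chain carbon, two bonds along the chain from an oxygen next to a carbonyl group, which amounts to ethyl becoming 6-(dimethylamino)hexyl. It lies on a saturated chain carbon, two bonds along the chain from an oxygen next to a carbonyl group.

Going by the values given here, the one measured step lies elsewhere on the molecule and has no readable size, so it gives no measure for this change. A modest shift towards less compound needed is expected, and compound 3 may well stay at the limit. The expected move is an at least 1.7-fold lower number from compound 2 to compound 3 (0.25 log units; that floor lies within the scatter). Compound 3 is estimated at 12000 nM, with an expected range from 4000 nM to 25000 nM.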

Compound 3, half-maximal effective concentration: > 21500 nM
Compound 3: a limit, no number; the forecaster's own chance of this, stated with the estimate: 40%; middle value at least 1.7-fold (0.25 log units) away from the limit.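

In this assay compound 3 gives > 21500 nM, which is a limit and not a number. Going by these compounds alone, compound 2 also stands at a limit, so no step from compound 2 to compound 3 can be read, and the three compounds sit together: the limit of > 21500 nM in this assay, at which 3 of the 3 values shown sit. The compounds shown leave open whether the 6-(dimethylamino)hexyl chain shifts the concentration needed at all, and by how much.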